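Threonine-derived amides in a liver-cell cytotoxicity assay

The source may report more compounds than this note shows. Statements on the series, on what has been measured and on what is new or still open speak of the compounds shown alone.

Measured in a functional assay on HepG2 cells (Homo sapiens) for cytotoxicity, read by MTT assay, with a stated time of 48 h; a higher number here means a weaker inhibitor, a lower number a stronger inhibitor:
- compound 1 `CCCCCCCCNC(=O)[C@@H](NC(=O)/C=C/c1ccccc1)[C@@H](C)O` gives 55600 nM
- compound 2 `C/C=C/C=C/C(=O)N[C@H](C(=O)NCCCCCCCC)[C@@H](C)O` gives 102000 nM
- compound 3 `CCCCCCCCCCCCNC(=O)[C@@H](NC(=O)/C=C/c1ccccc1)[C@@H](C)O` gives > 200000 nM

The value of compound 3 is a limit of the assay, not a number (the limit of > 200000 nM in this assay, at which 1 of the 3 values shown sits).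

From compound 1 to compound 2 the change is prop-1-en-1-yl in place of phenyl on a double-bonded chain carbon bound to a double-bonded chain carbon, and the step is a 1.8-fold higher number from compound 1 to compound 2 (0.26 log units; within the scatter). The two cores differ by butyl in place of hydrogen on a saturated chain carbon, eight bonds along the chain from an amide-type nitrogen, with a step of an at least 3.5-fold higher number from compound 1 to compound 3 (0.55 log units; beyond the scatter).

Compound 4 `C/C=C/C=C/C(=O)N[C@H](C(=O)NCCCCCCCCCCCC)[C@@H](C)O` remains to be measured in this assay. It carries the same change as compound 2, namely (prop-1-en-1-yl in place of phenyl on a double-bonded chain carbon bound to a double-bonded chain carbon), on the core of compound 3. Since that change moved compound 1 to compound 2 only within the scatter, and compound 3 already sits at the limit, compound 4 is expected to give a step that the limit leaves unreadable from compound 3 to compound 4. The estimate for compound 4 is 350000 nM, with a range from 150000 nM to 900000 nM, and most likely the assay will again report only a limit.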

Compound 4, half-maximal inhibitory concentration: > 400000 nM
Compound 4: only a limit was reported; the forecaster's own chance of this, stated with the estimate: 85%; at least 1.1-fold (0.05 log units) between middle value and limit.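

In this assay compound 4 gives > 400000 nM, a limit of the assay and not a number. The step from compound 3 to compound 4 cannot be read, so it remains unshown whether prop-1-en-1-yl in place of phenyl reads the same on the core of compound 3 as on the core of compound 1. Butyl in place of hydrogen on the saturated chain carbon, eight bonds along the chain from the amide-type nitrogen, gives an at least 3.9-fold higher number from compound 2 to compound 4 (0.59 log units; beyond the scatter), and this change points the same way on both cores: the same change on two cores in this assay, an at least 3.5-fold higher number (0.55 log units; beyond the scatter) from compound 1 to compound 3 and an at least 3.9-fold higher number (0.59 log units; beyond the scatter) from compound 2 to compound 4; the limit leaves it open whether they differ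

Still open, going by these compounds, is how a shorter chain, such as hexyl, would read on either core in this assay. Also open, on these data alone, is how a saturated chain in place of 2-phenylethenyl or penta-1,3-dien-1-yl would read.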